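Amide aryl change: 2-methylphenyl to 4-chlorophenyl

A few compounds are considered here, and "the series" means these few. Any claim that something is new, unique, unknown or untested is made for them only; others in the source may bear on it.

The series keeps one core and varies the aryl on the amide nitrogen. In a functional assay on MCF7 cells (Homo sapiens) for inhibition, read by MTT assay, with a stated time of 72 h (on this read-out lower numbers stand for stronger inhibition and higher numbers for weaker inhibition), compound 1 `Cc1ccc(NC(=O)c2ccc(/N=N\c3c[nH]c4ccccc34)cc2)c(C)c1` gives 87000 nM, compound 2 `COc1ccccc1NC(=O)c1ccc(/N=N\c2c[nH]c3ccccc23)cc1` gives 86500 nM, and compound 3 `Cc1ccccc1NC(=O)c1ccc(/N=N\c2c[nH]c3ccccc23)cc1` gives 73400 nM. Compound 3 sits alongside the other two: the steps of a 1.2-fold lower number from compound 1 to compound 3 (0.07 log units; within the scatter) and a 1.2-fold lower number from compound 2 to compound 3 (0.07 log units; within the scatter) are both within the scatter, as is a 1.0-fold lower number from compound 1 to compound 2 (0.00 log units; within the scatter). Compound 4 `O=C(Nc1ccc(Cl)cc1)c1ccc(/N=N\c2c[nH]c3ccccc23)cc1` carries 4-chlorophenyl in place of 2-methylphenyl on an amide-type nitrogen. The aryl swap between compound 1 and compound 2 bears most directly on this change, and the two single-substituent steps touch the same ring; none moved beyond the scatter. No step beyond the scatter is therefore expected in this assay, and the step of a 1.0-fold higher number from compound 3 to compound 4 (0.01 log units; within the scatter) is estimated as no change. Compound 4 is expected to give 75000 nM, within 38000 nM to 150000 nM.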

Compound 4, half-maximal inhibitory concentration: 107000 nM
For compound 4 the middle estimate is 1.4-fold (0.15 log units) below the measured one, within the range that was stated.
By their numbers in this assay, from the lowest: compounds 3, 2, 1 and 4 (each within the scatter of the next).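

In this assay the 4-chlorophenyl group on the amide-type nitrogen stays within the scatter of all three earlier aryls, with a 1.5-fold higher number from compound 3 to compound 4 (0.16 log units; within the scatter) and a 1.2-fold higher number from compound 2 to compound 4 (0.09 log units; within the scatter) and a 1.2-fold higher number from compound 1 to compound 4 (0.09 log units; within the scatter) as the steps. This position has now carried a chlorine-bearing aryl as well as methyl- and methoxy-bearing aryls, with no step beyond the scatter among the four compounds. No measurement shown bears on why these steps are as they are. Still open, on these data alone, is whether an aryl carrying a carboxylic acid or an amine would move the number beyond the scatter. As far as these compounds go, a longer alkyl chain on this nitrogen in place of the aryl is equally open.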